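Extending the Chain of Compound 3

The compounds below may be only part of what the source reports. "The series", "measured", "known", "first", "only" and "open" are said of these compounds alone.

In a functional assay on cells (Homo sapiens) for antiproliferative activity, read by sulforhodamine B assay, with a stated time of 48 h (a lower number here means a stronger inhibitor, a higher number a weaker inhibitor), compound 1 (`CCCCCCCCCCCCCCNC(=O)[C@@H]1CSC(c2cc(OC)c(OC)c(OC)c2)N1`) gives 2000 nM and compound 2 (`CCCCCCCCCCCCNC(=O)[C@@H]1CSC(c2ccc(OC)c(OC)c2)N1`) gives 2900 nM while compound 3 (`CCCCCCCCCCCCNC(=O)[C@@H]1CSC(c2ccc(NC(C)=O)cc2)N1`) gives 2400 nM and so stands within the scatter of both. Compound 4 (`CCCCCCCCCCCCCCCCCNC(=O)[C@@H]1CSC(c2ccc(NC(C)=O)cc2)N1`) differs from compound 3 by pentyl in place of hydrogen on a saturated chain carbon, ten or more bonds along the chain from an amide-type nitrogen at the end of the chain. Within the data shown here, the one measured step of a 1.2-fold lower number from compound 2 to compound 3 (0.08 log units; within the scatter) lies within the scatter and concerns 4-acetamidophenyl in place of 3,4-dimethoxyphenyl rather than the chain. Among the measured compounds shown here, compound 1 differs from compound 3 in more than one place, so no measured pair isolates chain length. No change beyond the scatter is therefore expected, and the estimated step is a 1.5-fold lower number from compound 3 to compound 4 (0.18 log units; within the scatter) in this measure. Compound 4 is expected at 1600 nM with an estimated range from 700 nM to 3500 nM as its likely span.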

Compound 4, half-maximal inhibitory concentration: 8500 nM
Estimate against measurement, compound 4: 5.3-fold (0.73 log units) below; measured number outside the range, above it.
By their numbers in this assay, from the lowest: compounds 1, 3 and 2 (each within the scatter of the next); then compound 4.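

In this assay, pentyl in place of hydrogen on a saturated chain carbon, ten or more bonds along the chain from an amide-type nitrogen, gives a 3.5-fold higher number from compound 3 to compound 4 (0.55 log units; beyond the scatter) and is the only step shown that lies beyond the scatter. This place on the chain therefore responds to added length, and in the wrong direction, which the earlier step at the 4-acetamidophenyl group could not show. No evidence given here accounts for this change.

The compounds shown leave open whether a shorter chain would hold the number of compound 3. They also leave open whether an amine or a carboxylic acid at this place would fare better than pentyl.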